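Swapping the Ester Group on the Thiophene Analogue

The source may hold more compounds than are shown below. What is called first, only, known or untested is meant among the compounds shown, and "the series" means these compounds.

Of the compounds shown here, three sharing one core have been measured in an assay on membranes from CHO cells for displacement of a labelled ligand from adenosine receptor A1 (Homo sapiens), read by scintillation counting, with a stated time of 60 min, tested at 1 uM; a lower number here means less inhibition, a higher number more inhibition at the concentration tested (going by the name of the read-out). Compound 1 `CC1=C(C(=O)OC2CCCCC2)C(c2ccoc2)NC(=O)N1` gives 15%. Compound 2 `CC1=C(C(=O)OCC2CC2)C(c2ccoc2)NC(=O)N1` gives 29%, and compound 3 `CC1=C(C(=O)OC2CCCCC2)C(c2cccs2)NC(=O)N1` gives 7%. Compound 4 `CC1=C(C(=O)OCC2CC2)C(c2cccs2)NC(=O)N1` has not yet been measured.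

Compound 2 differs from compound 1 by a single change: cyclopropylmethyl in place of cyclohexyl on an oxygen next to a carbonyl group. This change produced a number 14 percentage points higher from compound 1 to compound 2 (beyond the scatter). Compound 3 differs from compound 1 in its core: thiophen-2-yl in place of furan-3-yl on a saturated ring carbon. That change gave a number 8 percentage points lower from compound 1 to compound 3 (within the scatter), and compound 3 therefore stands with compound 1 rather than apart from it.

Compound 4 is reached from compound 3 by cyclopropylmethyl in place of cyclohexyl on an oxygen next to a carbonyl group. The group that leaves, the group that enters and the place on the oxygen are described in exactly the same words as for the change from compound 1 to compound 2, so this is the same change, made on the core of compound 3 instead of the core of compound 1. Among the four compounds this change occurs twice in all, and only one instance is measured. Because that instance gave a number 14 percentage points higher from compound 1 to compound 2 (beyond the scatter), a step of similar size is expected here, a number 14 percentage points higher from compound 3 to compound 4 (beyond the scatter). Whether the core of compound 3 answers this change in the same way as the core of compound 1 cannot be checked from these data, so the range is kept wide. Compound 4 is expected to give 21%, between 8% and 34%.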

Compound 4, a percentage reported as inhibition, at one concentration (the size of the read-out at that concentration, not a potency): 23%
The estimate for compound 4 lay 2 percentage points below the measured number; the range from low to high includes it.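

On the core of compound 3, cyclopropylmethyl in place of cyclohexyl on the oxygen gave a number 16 percentage points higher from compound 3 to compound 4 (beyond the scatter) in this assay, and this step closely matches the earlier one: the same change on two cores in this assay, a number 14 percentage points higher (beyond the scatter) from compound 1 to compound 2 and a number 16 percentage points higher (beyond the scatter) from compound 3 to compound 4, 2 percentage points apart, within the scatter of two such steps. Thiophen-2-yl in place of furan-3-yl, now with cyclopropylmethyl on the oxygen, gave a number 6 percentage points lower from compound 2 to compound 4 (within the scatter), and the ring change likewise looks the same with either group on the oxygen: the same change on two cores in this assay, a number 8 percentage points lower (within the scatter) from compound 1 to compound 3 and a number 6 percentage points lower (within the scatter) from compound 2 to compound 4, 2 percentage points apart, within the scatter of two such steps. Going by these compounds alone, this shows that within these four compounds each change kept its size when carried over, but it rests on only two cores and two ester groups, each read at a single concentration, so it does not show that the step would hold on other cores or reveal how potent any of the compounds is.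

The compounds shown leave open whether the same step would appear with a longer chain on the oxygen, or with an amide in place of the ester. They also leave open how a phenyl group would compare with furan-3-yl and thiophen-2-yl on the saturated ring carbon, and whether either change would still carry over there.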